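A Second Bromine on the Hydroxyphenyl Arm

The source may report more compounds than this note shows. Statements on the series, on what has been measured and on what is new or still open speak of the compounds shown alone.

Compound 1 `O=C(N/N=C/c1ccccc1)Nc1ccc(Oc2ccnc3[nH]ccc23)c(F)c1` is the parent of this small series. In a functional assay on HepG2 cells (Homo sapiens) for antiproliferative activity, read by MTT assay, with a stated time of 72 h (a lower number here means a stronger inhibitor, a higher number a weaker inhibitor), compound 1 gives 640 nM. Compound 2 `O=C(N/N=C/c1ccc(Br)cc1)Nc1ccc(Oc2ccnc3[nH]ccc23)c(F)c1` carries the change (bromo in place of hydrogen on an aromatic carbon); in this assay compound 2 gives 1000 nM, and the step of a 1.6-fold higher number from compound 1 to compound 2 (0.19 log units; within the scatter) is within the scatter. Compound 3 `O=C(N/N=C/c1ccc(O)c(Br)c1)Nc1ccc(Oc2ccnc3[nH]ccc23)c(F)c1` differs from compound 1 by 3-bromo-4-hydroxyphenyl in place of phenyl on a carbon with a double bond to nitrogen; in this assay compound 3 gives 1360 nM. The step of a 2.1-fold higher number from compound 1 to compound 3 (0.33 log units; beyond the scatter) is modest but beyond the scatter, while the step of a 1.4-fold higher number from compound 2 to compound 3 (0.13 log units; within the scatter) is within it, so compound 2 and compound 3 cannot be ordered against each other.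

Compound 4 `O=C(N/N=C/c1cc(Br)c(O)c(Br)c1)Nc1ccc(Oc2ccnc3[nH]ccc23)c(F)c1` has not yet been measured. It differs from compound 3 by bromo in place of hydrogen on an aromatic carbon. Within the data shown here, this is the same kind of change as the one from compound 1 to compound 2, but not the same change: in compound 2 the entering bromo sits para to a large group, whereas in compound 4 it sits ortho to a hydroxy group, meta to a bromo group and meta to a large group.

The earlier bromo step, a 1.6-fold higher number from compound 1 to compound 2 (0.19 log units; within the scatter), stayed within the scatter, and the step from compound 3 to compound 4 is expected to be of similar size, a 1.2-fold higher number from compound 3 to compound 4 (0.07 log units; within the scatter). Compound 4 is therefore expected to give about 1600 nM in this assay, with a likely range from 700 nM to 3600 nM.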

Compound 4, half-maximal inhibitory concentration: 6520 nM
Estimate against measurement, compound 4: 4.1-fold (0.61 log units) below, outside the stated range (above it).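

In this assay the entering bromo on compound 3 gives a 4.8-fold higher number from compound 3 to compound 4 (0.68 log units; beyond the scatter), and the full changes of arm give a 6.5-fold higher number from compound 2 to compound 4 (0.81 log units; beyond the scatter) and a 10-fold higher number from compound 1 to compound 4 (1.01 log units; beyond the scatter). The same replacement of hydrogen by bromo therefore does not carry over at one size from the phenyl arm of compound 1 to the 3-bromo-4-hydroxyphenyl arm of compound 3: the same change on two cores in this assay, a 1.6-fold higher number (0.19 log units; within the scatter) from compound 1 to compound 2 and a 4.8-fold higher number (0.68 log units; beyond the scatter) from compound 3 to compound 4, 3.1-fold (0.49 log units) apart, beyond the scatter of two such steps This rests on a single pair of steps, so it shows that the size of the bromo step differs between these two settings, but not whether the hydroxy group, the bromo group already present, or both together set that size, and it gives no general rule for the series.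

The compounds shown leave open whether the larger step belongs to bromo itself or would also appear with chloro or methyl entering at the same place, and whether it would remain if methoxy stood in place of the hydroxy group. They also leave open how an amine or a carboxylic acid on this arm would read in this assay, and whether the difference between the two steps would hold on a core other than the one shared here.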